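The compounds below may be only part of what the source reports. "The series", "measured", "known", "first", "only" and "open" are said of these compounds alone.

Compound 1 (`O=C1CS/C(=N/Nc2nncc3ccccc23)N1c1ccccc1`) gives 32 nM
Compound 2 (`S=C(NNc1nncc2ccccc12)Nc1ccccc1`) gives 77 nM

These values come from a functional assay on COLO 205 cells (Homo sapiens) for antiproliferative activity, read by sulforhodamine B assay, with a stated time of 72 h (on this read-out higher numbers stand for weaker inhibition and lower numbers for stronger inhibition), and describe how strongly each compound holds back cell growth. Of the two, compound 2 has the higher number, 77 nM in this case, so it is the weaker inhibitor, and its gap to compound 1 lies beyond the usual scatter.

Compound 3 (`COc1ccc(NC(=S)NNc2nncc3ccccc23)cc1`) differs from compound 2 in a single place: methoxy in place of hydrogen on an aromatic carbon (methoxy in place of hydrogen on an aromatic carbon, para to a large group). Among the measured compounds shown here, no measured pair here shows what such a swap does in this assay and so the direction remains open. A small change, none beyond the scatter, is the most reasonable expectation. The estimated step of a 1.1-fold lower number from compound 2 to compound 3 (0.04 log units; within the scatter) is accordingly expected to be slight. For compound 3 the estimated value is 70 nM with an expected range from 20 nM to 250 nM as the likely span.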

Compound 3, half-maximal inhibitory concentration: 67 nM
Compound 3: middle estimate off by 1.0-fold (0.02 log units), on the high side, and the stated range covers the measured number.
By their numbers in this assay, from the lowest: compound 1; then compounds 3 and 2 (each within the scatter of the next).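

Putting methoxy in place of hydrogen on this aromatic carbon, para to a large group, gives a 1.1-fold lower number from compound 2 to compound 3 (0.06 log units; within the scatter) in this assay, so the two compounds cannot be told apart on this read-out. Among the compounds shown here, this is the first measured look at this position, and it shows that the position can take methoxy while the number stays within the ordinary spread of repeat measurements. The data offer no explanation for this result.

From the compounds shown here alone, a single swap at a single position cannot show how other groups would fare, so it remains open whether an amine, a carboxylic acid or a longer chain such as butoxy on this same carbon would also leave the number in place. Going by these compounds, it is equally open whether the same methoxy swap would give a similar result on compound 1.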